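From 4-hydroxyphenyl to 2,6-dimethoxyphenyl in a short series

This account rests on a few compounds, and the source may have more. Where it says the series, first, only, none or still open, it means among the compounds named here.

In a functional assay on MDA-MB-435 cells (Homo sapiens) for inhibition, read by sulforhodamine B assay, with a stated time of 48 h (on this read-out higher numbers stand for weaker inhibition of growth and lower numbers for stronger inhibition of growth), compound 1 (`O=C(Cc1csc2nc(-c3ccc(Br)cc3)cn12)N/N=C/c1ccccc1`), which has no hydroxy group, gives 51300 nM. Compound 2 (`O=C(Cc1csc2nc(-c3ccc(Br)cc3)cn12)N/N=C/c1ccccc1O`) gives 13500 nM, and compound 3 (`O=C(Cc1csc2nc(-c3ccc(Br)cc3)cn12)N/N=C/c1ccc(O)cc1`) gives 24500 nM. Compound 3 therefore stands within the scatter of compound 2, the step being a 1.8-fold higher number from compound 2 to compound 3 (0.26 log units; within the scatter), and modestly apart from compound 1.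

The next compound is compound 4 (`COc1cccc(OC)c1/C=N/NC(=O)Cc1csc2nc(-c3ccc(Br)cc3)cn12`), with 2,6-dimethoxyphenyl in place of 4-hydroxyphenyl on a carbon with a double bond to nitrogen.

Going by the values given here, two measured steps bear on this change, a 3.8-fold lower number from compound 1 to compound 2 (0.58 log units; beyond the scatter) and a 2.1-fold lower number from compound 1 to compound 3 (0.32 log units; beyond the scatter), both modest and beyond the scatter. Among the compounds with values here, compound 4 has no hydroxy group, which would point back towards compound 1, but no methoxy compound has been measured, so this guide is weak. The expected change is small, a 1.3-fold higher number from compound 3 to compound 4 (0.12 log units; within the scatter), and no step beyond the scatter is expected. For compound 4 the estimated value is 32000 nM, with an expected range of 11000 nM to 85000 nM.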

Compound 4, concentration for total growth inhibition: 16200 nM
Estimate against measurement, compound 4: 2.0-fold (0.30 log units) above; the range from low to high includes it.
By their numbers in this assay, from the lowest: compounds 2, 4 and 3 (each within the scatter of the next); then compound 1.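

Compound 4 carries 0 hydrogen-bond donors, yet a 3.2-fold lower number from compound 1 to compound 4 (0.50 log units; beyond the scatter) is a modest step beyond the scatter, so in this assay the move away from plain phenyl does not depend on a hydroxy group. The steps to the two hydroxy compounds, a 1.5-fold lower number from compound 3 to compound 4 (0.18 log units; within the scatter) and a 1.2-fold higher number from compound 2 to compound 4 (0.08 log units; within the scatter), both lie within the scatter, which puts 2,6-dimethoxyphenyl on a level with 2-hydroxyphenyl and 4-hydroxyphenyl at this carbon, with no order among the three. No measurement at hand gives a reason for this result.

Open, going by these compounds, is whether a single methoxy group would be enough or both are needed for this level. Also open, on these data alone, is whether a different kind of group on the phenyl ring, such as an amine or a carboxylic acid, would move the number away from that of compounds 2, 3 and 4.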